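This account rests on a few compounds, and the source may have more. Where it says the series, first, only, none or still open, it means among the compounds named here.

Compound 1 `COc1ccc(C2CC(c3ccccc3)=NN2c2nc(-c3ccccc3)c(C#N)c(=O)n2C)cc1`: 14700 nM
Compound 2 `COc1ccc(C2CC(c3ccc(Cl)cc3)=NN2c2nc(-c3ccccc3)c(C#N)c(=O)n2C)cc1`: 9120 nM

For the measured compounds named here, in a functional assay on HT-29 cells (Homo sapiens) for antiproliferative activity, with a stated time of 72 h (a lower number here means a stronger inhibitor, a higher number a weaker inhibitor), compound 2 stands at the lower of the two numbers, though only by a margin within the scatter; the single measured step, a 1.6-fold lower number from compound 1 to compound 2 (0.21 log units; within the scatter), put chloro in place of hydrogen on an aromatic carbon.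

Compound 3 `COc1ccc(C2=NN(c3nc(-c4ccccc4)c(C#N)c(=O)n3C)C(c3ccc(OC)cc3)C2)cc1` differs from compound 2 by methoxy in place of chloro on an aromatic carbon. Going by the values given here, no measured step swaps chloro for methoxy, so that one small step at the same place is the only guide. Compound 3 is therefore expected to show no step beyond the scatter, a 1.2-fold higher number from compound 2 to compound 3 (0.08 log units; within the scatter). For compound 3 the estimate is 11000 nM, ranging from 3500 nM to 35000 nM.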

Compound 3, half-maximal inhibitory concentration: 9420 nM
Beside the measured number, compound 3's estimate is 1.2-fold (0.07 log units) above it, and the stated range covers the measured number.
By their numbers in this assay, from the lowest: compounds 2, 3 and 1 (each within the scatter of the next).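

In this assay, the swap from 4-chlorophenyl to 4-methoxyphenyl gives a 1.0-fold higher number from compound 2 to compound 3 (0.01 log units; within the scatter) at this place para to a large group, while methoxy in place of hydrogen gives a 1.6-fold lower number from compound 1 to compound 3 (0.19 log units; within the scatter) on the same ring. With these steps, hydrogen, chloro and methoxy all lie within the scatter of one another, so a second substituent at this position, one that adds an oxygen, still does not separate from the others. No evidence here bears on this result.

Going by these compounds, whether an amine or a carboxylic acid at this position would give a step beyond the scatter remains open. So does whether any change elsewhere on the shared core would do so.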